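Changing the Aryl Group on the Ring Nitrogen

The compounds below may be only part of what the source reports. "The series", "measured", "known", "first", "only" and "open" are said of these compounds alone.

Of the compounds shown here, three sharing one core have been tested in an assay on Sf9 cells for inhibition of protein deacetylase HDAC6 (Homo sapiens), read by fluorescence, with a stated time of 40 min, tested at 100 nM; a higher number here means more inhibition at the concentration tested (going by the name of the read-out), a lower number less inhibition. For the measured compounds named here, compound 1 `O=C(NO)c1ccc(NCc2nc(-c3ccccc3)nn2-c2cccc(Cl)c2)cc1` gives 62.3%, compound 2 `Cc1ccccc1-n1nc(-c2ccccc2)nc1CNc1ccc(C(=O)NO)cc1` gives 57.1%, and compound 3 `O=C(NO)c1ccc(NCc2nc(-c3ccccc3)nn2-c2ccc(F)cc2)cc1` gives 67.6%, the highest of the three numbers, although the step of a number 5.3 percentage points higher from compound 1 to compound 3 (within the scatter) lies within the scatter; only the step of a number 10.5 percentage points higher from compound 2 to compound 3 (beyond the scatter) goes beyond it, while the step of a number 5.2 percentage points lower from compound 1 to compound 2 (within the scatter) does not. Compound 4 `Cc1cc(C)cc(-n2nc(-c3ccccc3)nc2CNc2ccc(C(=O)NO)cc2)c1` differs from compound 3 by 3,5-dimethylphenyl in place of 4-fluorophenyl on an aromatic nitrogen. Going by the values given here, the earlier swaps at this position moved the read-out only a little, with compound 2, which carries a methyl group, involved in the one step beyond the scatter. A similarly small step is therefore expected, a number 9.6 percentage points lower from compound 3 to compound 4 (within the scatter), most likely downward but not clearly beyond the scatter. Compound 4 is estimated at 58%, within 45% to 70%.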

Compound 4, a percentage reported as inhibition, at one concentration (the size of the read-out at that concentration, not a potency): 49.8%
Compound 4: the middle estimate sits 8.2 percentage points above what was measured; the range from low to high includes it.
By their numbers in this assay, from the lowest: compounds 4, 2, 1 and 3 (each within the scatter of the next, the first and the last beyond it).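

In this assay this position can move the read-out further than the earlier swaps suggested: the step of a number 17.8 percentage points lower from compound 3 to compound 4 (beyond the scatter) is the largest so far, and the step of a number 12.5 percentage points lower from compound 1 to compound 4 (beyond the scatter) also clears the scatter. The two methyl-bearing compounds stay close together, as the step of a number 7.3 percentage points lower from compound 2 to compound 4 (within the scatter) shows, yet compound 2 is not separated from compound 1, so methyl alone does not sort this set. No measured evidence here explains these steps. Still open, as far as these compounds go, is how an amine, a carboxylic acid or a methoxy group on this phenyl ring would read.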